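The source may report more compounds than this note shows. Statements on the series, on what has been measured and on what is new or still open speak of the compounds shown alone.

Measured so far, in an ADME assay on microsomes from liver (Homo sapiens) for metabolic stability, tested at 2.5 uM; a higher number here means faster removal of the compound, a lower number slower removal: compound 1 `O=S(=O)(c1ccc(F)c(Cl)c1)c1cnc2c(F)cccc2c1-c1ccccc1F` gives 1.39 mL/min; compound 2 `O=S(=O)(c1cccc(F)c1)c1cnc2c(F)cccc2c1-c1ccccc1F` gives 0.21 mL/min.

Within the data shown here, compound 1 stands highest of the two numbers, and the only other number lies well below it, reached by a 6.6-fold lower number from compound 1 to compound 2 (0.82 log units; beyond the scatter). Compound 3 `O=S(=O)(c1ccc(F)c(Cl)c1)c1cnc2c(F)cccc2c1-c1cccc(F)c1` differs from compound 1 elsewhere: 3-fluorophenyl in place of 2-fluorophenyl on an aromatic carbon. Among the measured compounds shown here, the single measured step concerns the group on the sulfonyl sulfur, not the group changed here, so no measured step bears directly on this change. For the measured compounds named here, with no such step to draw on, compound 3 is expected to shift by only a 1.2-fold lower number from compound 1 to compound 3 (0.06 log units; within the scatter), within the scatter. Compound 3 is therefore estimated at 1.2 mL/min, with a range from 0.5 mL/min to 2.8 mL/min.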

Compound 3, intrinsic clearance in a liver preparation (reported as CLH), per the amount of preparation that the assay uses: 1.23 mL/min
The estimate for compound 3 lay 1.0-fold (0.01 log units) below the measured number; the range from low to high includes it.
By their numbers in this assay, from the lowest: compound 2; then compounds 3 and 1 (each within the scatter of the next).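

In this assay, 3-fluorophenyl in place of 2-fluorophenyl on this aromatic carbon gives a 1.1-fold lower number from compound 1 to compound 3 (0.05 log units; within the scatter) and so leaves no readable difference between the two fluorophenyl groups at this position. Among these compounds, the only step here beyond the scatter remains the one on the sulfonyl sulfur. Nothing available explains this result. From the compounds shown here alone, whether an unsubstituted phenyl, a pyridine or a morpholine at this position would read the same remains open. Going by these compounds, it is also open whether 3-fluorophenyl here would read the same with the sulfonyl group of compound 2.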